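Trading a pyridine-bearing sulfanyl group for isopropoxy

The source may report more compounds than this note shows. Statements on the series, on what has been measured and on what is new or still open speak of the compounds shown alone.

In a functional assay on MV4-11 cells (Homo sapiens) for inhibition, read by resazurin assay, with a stated time of 72 h (a higher number here means a weaker inhibitor of growth, a lower number a stronger inhibitor of growth), compound 1 `COc1ccc(Nc2nccc(-c3sc(SC)nc3C)n2)c(OC)c1` gives 530 nM, compound 2 `COCCOc1nc(C)c(-c2ccnc(Nc3ccc(OC)cc3OC)n2)s1` gives 1980 nM and compound 3 `COc1ccc(Nc2nccc(-c3sc(SCc4cccnc4)nc3C)n2)c(OC)c1` gives 270 nM. Compound 3 has the lowest number of the three, although its gap to compound 1 lies within the scatter, and only compound 2 stands clearly apart.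

Compound 4 `COc1ccc(Nc2nccc(-c3sc(OC(C)C)nc3C)n2)c(OC)c1` has isopropoxy in place of ((pyridin-3-yl)methyl)sulfanyl on an aromatic carbon.

The closest guide is the swap between the same sulfanyl group and an oxygen-linked chain, which gives a 7.3-fold lower number from compound 2 to compound 3 (0.87 log units; beyond the scatter). Replacing methylsulfanyl with 2-methoxyethoxy points the same way, with a 3.7-fold higher number from compound 1 to compound 2 (0.57 log units; beyond the scatter). Adding the pyridine mattered little, with a 2.0-fold lower number from compound 1 to compound 3 (0.29 log units; within the scatter). Among the measured compounds shown here, compound 2 is the only oxygen-linked example, so this guide is thin. A clear rise of somewhat smaller size is therefore expected in this assay, and the expected change is a 5.2-fold higher number from compound 3 to compound 4 (0.71 log units; beyond the scatter). Compound 4 is estimated at 1400 nM, within an expected range of 500 nM to 4000 nM.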

Compound 4, concentration for 50% growth inhibition: 8690 nM
Beside the measured number, compound 4's estimate is 6.2-fold (0.79 log units) below it, and the stated range ends below it.
By their numbers in this assay, from the lowest: compounds 3 and 1 (each within the scatter of the next); then compound 2; then compound 4.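

In this assay, among the compounds shown here, isopropoxy on this aromatic carbon gives up far more than the single oxygen-linked example, compound 2, had indicated (a 32-fold higher number from compound 3 to compound 4 (1.51 log units; beyond the scatter)), and the loss is also large against the small methylsulfanyl group (a 16-fold higher number from compound 1 to compound 4 (1.21 log units; beyond the scatter)). An oxygen link alone therefore does not fix the number at this position, as the chain on the oxygen matters too: swapping 2-methoxyethyl for isopropyl gives a further rise (a 4.4-fold higher number from compound 2 to compound 4 (0.64 log units; beyond the scatter)). Nothing measured here explains why these changes have these effects.

From the compounds shown here alone, what remains open is how much of the loss belongs to the oxygen link and how much to the isopropyl chain. An isopropylsulfanyl group would separate the two, and a methylamino group would show how a nitrogen link behaves at this carbon.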